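Removing a ring nitrogen methyl in a series without agonism

This account rests on a few compounds, and the source may have more. Where it says the series, first, only, none or still open, it means among the compounds named here.

Three compounds of this series were examined in a functional assay on CCRF-CEM cells for agonist activity at C-X-C chemokine receptor type 4 (Homo sapiens), read by calcium flux, with a stated time of 25 min (on this read-out lower numbers stand for an effect already at smaller amounts and higher numbers for an effect only at larger amounts of compound), and none gave a number. Compound 1 `c1cnc2c(c1)CCC[C@@H]2N(CC1CC1)C[C@H]1Cc2c(cccc2N2CCNCC2)CN1` reaches only the limit of the assay, > 30000 nM. Compound 2 `FC1(F)CCC(CN(C[C@H]2Cc3c(cccc3N3CCNCC3)CN2)[C@H]2CCCc3cccnc32)CC1` likewise reaches only the limit, > 30000 nM. Compound 3 `CN1CCN(c2cccc3c2C[C@H](CN(C)[C@H]2CCCc4cccnc42)NC3)CC1` also stops at the limit, > 30000 nM. Hence compound 3 stands exactly where the other two stand, at the limit described by the limit of > 30000 nM in this assay, at which 3 of the 3 values shown sit, and nothing separates the three.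

For the measured compounds named here, the one step between measured compounds, a step that the two limits leave unreadable from compound 1 to compound 2, is 4,4-difluorocyclohexyl in place of cyclopropyl on a saturated chain carbon bound to an amine nitrogen; because both ends sit at the limit (the limit of > 30000 nM in this assay, at which 3 of the 3 values shown sit), its size cannot be read.

The unmeasured compound 4 `CN(C[C@H]1Cc2c(cccc2N2CCNCC2)CN1)[C@H]1CCCc2cccnc21` differs from compound 3 by hydrogen in place of methyl on an amine nitrogen in a ring. Going by the values given here, no measured step addresses this change, and the only evidence is that every value so far lies at the limit (the limit of > 30000 nM in this assay, at which 3 of the 3 values shown sit). The expectation for compound 4 in this assay is therefore no effect within the measured range, a step of a number no higher from compound 3 to compound 4 (the limit leaves the size open) not distinguishable from none. Compound 4 is estimated at 30000 nM, with a range from 10000 nM to 100000 nM.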

Compound 4, half-maximal effective concentration: > 30000 nM
Compound 4 was reported as a limit; the forecaster's own chance of this, stated with the estimate: 85%; the middle value lies on the limit itself.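

The steps to compound 4 from compound 1, compound 2 and compound 3 have limits at both ends, so no new step can be read from this result: the limit of > 30000 nM in this assay, at which 4 of the 4 values shown sit.

The compounds shown leave open whether any member of this series gives agonism in this assay, and how large any of these changes would be.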